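A few compounds are considered here, and "the series" means these few. Any claim that something is new, unique, unknown or untested is made for them only; others in the source may bear on it.

The measured compounds:
compound 1 `CCOC(=O)c1sc(NC(=O)Cn2cc(-c3cccs3)nn2)nc1C`: 20 nM
compound 2 `O=C(Cn1cc(-c2ccc([N+](=O)[O-])cc2)nn1)Nc1nccs1`: 1040 nM

In a functional assay on BMDM cells (Mus musculus, strain C57BL/6) for inhibition, with a stated time of 2 days (on this read-out lower numbers stand for stronger inhibition and higher numbers for weaker inhibition), compound 1 gives 20 nM, the lowest of the two numbers. Compound 2 gives 1040 nM, a higher number beyond the scatter, but compound 2 differs from compound 1 in more than one place, so the pair shows only that gap. Compound 3 `CCOC(=O)c1sc(NC(=O)Cn2cc(-c3ccc(OC)cc3)nn2)nc1C` differs from compound 1 in one place: 4-methoxyphenyl in place of thiophen-2-yl on an aromatic carbon. Going by the values given here, no measured pair shows this kind of change, so the direction is uncertain. A step from compound 1 to compound 3 of a 2.3-fold higher number from compound 1 to compound 3 (0.35 log units; beyond the scatter) toward a higher number is expected. Compound 3 is estimated at 45 nM, with a range from 10 nM to 250 nM.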

Compound 3, half-maximal inhibitory concentration: 2330 nM
The estimate for compound 3 lay 52-fold (1.71 log units) below the measured number, outside the stated range (above it).
By their numbers in this assay, from the lowest: compound 1; then compound 2; then compound 3.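

Putting 4-methoxyphenyl in place of thiophen-2-yl on an aromatic carbon of the five-membered aromatic ring with 3 nitrogen gives, in this assay, a 120-fold higher number from compound 1 to compound 3 (2.07 log units; beyond the scatter). With the rest of compound 1 unchanged, this one position alone can carry a large shift in the number, which the earlier pair, differing in more than one place, could not show. Nothing shown here gives a reason for this step. From the compounds shown here alone, it remains open whether the shift follows the six-membered ring or the methoxy group, and how plain phenyl, furan-2-yl or a pyridine ring would read at this position.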